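Methoxy for chloro on the anilino ring of compound 1

A few compounds are considered here, and "the series" means these few. Any claim that something is new, unique, unknown or untested is made for them only; others in the source may bear on it.

Measured compounds in a functional assay on MCF7 cells (Homo sapiens) for cytotoxicity, read by MTT assay, with a stated time of 72 h; on this read-out lower numbers stand for stronger inhibition and higher numbers for weaker inhibition:
compound 1 `CCOC(=O)c1c(C)oc2ncnc(Nc3cccc(Cl)c3)c12`: > 1000000 nM
compound 2 `CCOC(=O)c1c(C)oc2ncnc(Nc3ccc(OCc4cccc(F)c4)c(Cl)c3)c12`: 257000 nM
compound 3 `Cc1oc2ncnc(Nc3cccc(Cl)c3)c2c1C(=O)O`: 57500 nM

In this assay compound 1 gives only a limit, > 1000000 nM, and no number. Compound 1 thus stands at the weak end of the three, at the limit described by the limit of > 1000000 nM in this assay, at which 1 of the 3 values shown sits. Compound 2 gives 257000 nM and compound 3 gives 57500 nM, so both give smaller numbers than compound 1: the step of an at least 3.8-fold lower number from compound 1 to compound 2 (0.59 log units; beyond the scatter) is at least modest and the step of an at least 17-fold lower number from compound 1 to compound 3 (1.24 log units; beyond the scatter) is large.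

Compound 4 `CCOC(=O)c1c(C)oc2ncnc(Nc3cccc(OC)c3)c12` differs from compound 1 in one place: methoxy in place of chloro on an aromatic carbon. Neither measured step touches this place; one adds (3-fluorobenzyl)oxy on an aromatic carbon, the other puts hydrogen in place of ethyl on an oxygen next to a carbonyl group. Going by the values given here, no measured step therefore bears on the change to compound 4, and no step beyond the scatter is expected from it in this assay. The estimate for compound 4 is 1500000 nM, between 200000 nM and 10000000 nM, which is expected to mean a step that the limit leaves unreadable from compound 1 to compound 4, with the result most likely again reported only as a limit.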

Compound 4, half-maximal inhibitory concentration: > 1000000 nM
Compound 4 ended at the assay's limit (the forecaster's own chance of this, stated with the estimate: 70%); the middle value is on the limit's open side.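

In this assay compound 4 gives > 1000000 nM as a limit of the assay and not a number. Compound 1 also stands at a limit, so the step between compound 1 and compound 4 cannot be read. As far as these compounds go, whether 3-methoxyphenyl and 3-chlorophenyl on the shared core differ at all in this assay stays open.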